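The source may report more compounds than this note shows. Statements on the series, on what has been measured and on what is new or still open speak of the compounds shown alone.

Measured compounds:
compound 1 `CC(C)(CN)CCN(C[C@H]1Cc2ccccc2CN1)[C@H]1CCCc2cccnc21` — 69 nM
compound 2 `C(=C/CN(C[C@H]1Cc2ccccc2CN1)[C@H]1CCCc2cccnc21)\CNCC1CCOCC1` — 24.2 nM

In a functional assay on cells for antagonist activity at C-X-C chemokine receptor type 4 (Homo sapiens), read by fluorescence and calcium flux, with stated times of 25 min and 90 s (a higher number here means a weaker inhibitor, a lower number a stronger inhibitor), compound 1 gives 69 nM, and compound 2 gives 24.2 nM. Among the measured compounds shown here, compound 2 therefore stands lowest of the two numbers, and its only neighbour is compound 1, separated by the single measured step of a 2.9-fold lower number from compound 1 to compound 2 (0.46 log units; beyond the scatter), which is modest but beyond the scatter.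

Compound 3 `FC1(F)CCC(NC/C=C/CN(C[C@H]2Cc3ccccc3CN2)[C@H]2CCCc3cccnc32)CC1` is the next compound to be measured. It differs from compound 2 by 4,4-difluorocyclohexyl in place of (oxan-4-yl)methyl on an amine nitrogen. For the measured compounds named here, only the step from compound 1 to compound 2 offers any guidance, and it changed both the chain and the end group at once, so it speaks to the new change only indirectly. Going by the values given here, with one modest step as the sole precedent, a change confined to the group on the amine nitrogen is expected to move the number little, if at all, beyond the scatter. Compound 3 is therefore estimated at 30 nM, within a range of 10 nM to 90 nM, which corresponds to an expected step of a 1.2-fold higher number from compound 2 to compound 3 (0.09 log units; within the scatter).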

Compound 3, half-maximal inhibitory concentration in the C-X-C chemokine receptor type 4 assay: 82.1 nM
The estimate for compound 3 lay 2.7-fold (0.44 log units) below the measured number; the measured number falls inside the stated range.
By their numbers in the C-X-C chemokine receptor type 4 assay, from the lowest: compound 2; then compounds 1 and 3 (each within the scatter of the next).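

Changing the group on the amine nitrogen matters in the C-X-C chemokine receptor type 4 assay: 4,4-difluorocyclohexyl in place of (oxan-4-yl)methyl gives a 3.4-fold higher number from compound 2 to compound 3 (0.53 log units; beyond the scatter). The step from compound 1 to compound 2 altered the chain and the end group together, whereas this step alters only the end group, so the group on this nitrogen alone can shift the number beyond the scatter. In a physicochemical assay for permeability, using PAMPA, with a stated time of 4 h, at pH 5.5, tested at 100 uM (a lower number here means that the compound crosses the layer more slowly, a higher number that the compound crosses the layer faster), compound 2 gives 33.5 nm/s, and compound 3 gives 9 nm/s. The same change also slows passage across the layer in the physicochemical assay: the measured apparent permeability of compound 2, 33.5 nm/s, and of compound 3, 9 nm/s, a 3.7-fold lower number (0.57 log units; beyond the scatter)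

As far as these compounds go, two features differ at once here, the ring oxygen and the methyl link to the nitrogen, so their separate contributions remain open; plain oxan-4-yl or (cyclohexyl)methyl on the same nitrogen would help to separate them. Whether the two shifts are connected also cannot be told from these compounds.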